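The source may report more compounds than this note shows. Statements on the series, on what has been measured and on what is new or still open speak of the compounds shown alone.

Compound 3 `COc1cc(C)c(S(=O)(=O)N(C)CCOCC(=O)N2CCN(CCCN(C)C)CC2)c(C)c1` is the weakest crosser of the three measured compounds: in an ADME assay on Caco-2 cells (Homo sapiens) for permeability, tested at 50 uM (a higher number here means that the compound crosses the layer faster, a lower number that the compound crosses the layer more slowly), compound 3 gives 0.1 10^-6 cm/s. Compound 1 `CCN(CC)CCN1CCN(C(=O)COCCN(C)S(=O)(=O)c2c(C)cc(OC)cc2C)CC1` gives 0.9 10^-6 cm/s and compound 2 `COc1cc(C)c(S(=O)(=O)N(C)CCOCC(=O)N2CCN([C@@H]3CN4CCC3CC4)CC2)c(C)c1` gives 1.4 10^-6 cm/s; the two are separated by a 1.6-fold higher number from compound 1 to compound 2 (0.19 log units; within the scatter). From those two compounds the numbers drop to compound 3, by a 9.0-fold lower number from compound 1 to compound 3 (0.95 log units; beyond the scatter) and by a 14-fold lower number from compound 2 to compound 3 (1.15 log units; beyond the scatter).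

Compound 4 `COc1cc(C)c(S(=O)(=O)N(C)CCOCC(=O)N2CCN([C@H]3CN4CCC3CC4)CC2)c(C)c1` is the next compound to be measured. It differs from compound 3 at one place: a group of 8 heavy atoms (7 carbon, 1 nitrogen; 2 six-membered non-aromatic rings with 1 hetero atom each) in place of a group of 6 heavy atoms (5 carbon, 1 nitrogen; no ring), on an amine nitrogen in a ring. The entering group is the same ring pair found in compound 2, with its stereocentre set the other way, so the step from compound 2 to compound 3 read in reverse is the direct guide, and that step was large. The step from compound 1 to compound 3, a related chain-to-chain swap, points the same way. A rise in apparent permeability beyond the scatter is therefore expected for compound 4, roughly a 12-fold higher number from compound 3 to compound 4 (1.08 log units; beyond the scatter). In this assay compound 4 is estimated at 1.2 10^-6 cm/s, with a likely range from 0.5 10^-6 cm/s to 3 10^-6 cm/s.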

Compound 4, apparent permeability: 1.9 10^-6 cm/s
Compound 4: middle estimate off by 1.6-fold (0.20 log units), on the low side, and the stated range covers the measured number.
By their numbers in this assay, from the lowest: compound 3; then compounds 1, 2 and 4 (each within the scatter of the next, the first and the last beyond it).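

The ring pair on the amine nitrogen in a ring lifts the number a second time, with a 19-fold higher number from compound 3 to compound 4 (1.28 log units; beyond the scatter), so the large gap to the 3-(dimethylamino)propyl chain holds for both drawn forms of the stereocentre. The two forms differ only at a saturated ring carbon, and a 1.4-fold higher number from compound 2 to compound 4 (0.13 log units; within the scatter) leaves them within the scatter, a reading that carries one caution: the fact that one of compounds 2 and 4 is drawn with a defined configuration and the other without, at the place where they differ. Against the open chain of 7 heavy atoms, this form gives a 2.1-fold higher number from compound 1 to compound 4 (0.32 log units; beyond the scatter), while the other form gives a 1.6-fold higher number from compound 1 to compound 2 (0.19 log units; within the scatter), so that modest edge rests on one form alone.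

The compounds shown leave open whether both rings of the pair are needed, or whether a single piperidine ring would serve as well. They also leave open how a 2-(dimethylamino)ethyl chain would compare.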